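This account rests on a few compounds, and the source may have more. Where it says the series, first, only, none or still open, it means among the compounds named here.

Compound 1 `COc1cc(/C=C/C(=O)/C=C/c2cccs2)ccc1OCc1cn(CCOc2cc(=O)oc3ccccc23)nn1` and compound 2 `COc1ccccc1/C=C/C(=O)/C=C/c1ccc(OCc2cn(CCCCOc3cc(=O)oc4ccccc34)nn2)c(OC)c1` share a core in which a carbonyl sits between two double bonds, each carrying an aromatic ring, and both were tested in a functional assay on HCT-116 cells (Homo sapiens) for inhibition, read by sulforhodamine B assay, with a stated time of 48 h, tested at 50 uM; a lower number here means less inhibition of growth, a higher number more inhibition of growth at the concentration tested. Compound 1 gives 71% and stands highest of the two numbers; compound 2 gives 43%, a gap beyond the usual scatter, though these two compounds differ in more than one place, so nothing about a single change can be read from that gap alone.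

Compound 3 `COc1ccc(/C=C/C(=O)/C=C/c2ccc(OCc3cn(CCOc4cc(=O)oc5ccccc45)nn3)c(OC)c2)cc1OC` differs from compound 1 in one place: 3,4-dimethoxyphenyl in place of thiophen-2-yl on a double-bonded chain carbon bound to a double-bonded chain carbon. For the measured compounds named here, no step between measured compounds matches this change, so the expectation rests on compound 1 alone together with the lower number of compound 2. A modest fall is expected for compound 3 in this assay, a step of a number 13 percentage points lower from compound 1 to compound 3 (beyond the scatter) that may not exceed the scatter. Compound 3 is estimated at 58%, within a range from 35% to 80%.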

Compound 3, percent growth inhibition at one concentration: 82%
Compound 3: middle estimate off by 24 percentage points, on the low side; the whole stated range lies below it.
By their numbers in this assay, from the lowest: compound 2; then compound 1; then compound 3.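

For the compounds shown here, until now no two measured compounds differed at this place, on a double-bonded chain carbon bound to a double-bonded chain carbon, so the effect of changing the group there could not be read. In this assay, 3,4-dimethoxyphenyl in place of thiophen-2-yl gives a number 11 percentage points higher from compound 1 to compound 3 (beyond the scatter), which shows that this position accepts a group of 10 heavy atoms in place of one of 5 without any loss of growth inhibition, and with a gain here. Nothing measured here explains this rise.

This is a single swap at a single test concentration, so it does not show whether the gain comes from the six-membered ring or from its two methoxy groups. Also open, from the compounds shown here alone, is how a plain phenyl ring, a furan-2-yl ring or a phenyl ring carrying a carboxylic acid would fare at this place.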